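One Carbon Shorter in the Chain: Compound 3

The source may report more compounds than this note shows. Statements on the series, on what has been measured and on what is new or still open speak of the compounds shown alone.

Measured so far:
compound 1 `O=C(CCCCCCN(Cc1ccc(F)cc1)c1ncc(C(=O)NCCCn2ccnc2)s1)NO` gives 9700 nM
compound 2 `O=C(CCCCCCN(Cc1ccc(F)cc1)c1ncc(C(=O)NCc2cccnc2)s1)NO` gives 17000 nM

Both numbers come from a functional assay on HCT-116 cells (Homo sapiens) for inhibition, read by MTT assay, with a stated time of 72 h (a higher number here means a weaker inhibitor, a lower number a stronger inhibitor), a cell-growth test in which a low number marks a compound that stops growth at a small concentration. Compound 1 and compound 2 share their core and differ only in the group on the amide side; the step of a 1.8-fold higher number from compound 1 to compound 2 (0.24 log units; within the scatter) lies within the scatter, so on these two numbers compound 1 stands alongside compound 2 rather than apart from it.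

Compound 3 `O=C(CCCCCN(Cc1ccc(F)cc1)c1ncc(C(=O)NCCCn2ccnc2)s1)NO` is the next variation: hydroxycarbamoyl in place of (hydroxycarbamoyl)methyl on a saturated chain carbon, five bonds along the chain from a nitrogen on an aromatic ring. Among the measured compounds shown here, this change touches the chain that carries the hydroxycarbamoyl end, a part left untouched in the only measured step, which concerned the other side of the molecule. For the measured compounds named here, no measured step therefore bears on it, and the data give no basis for expecting a move beyond the scatter in either direction in this assay, though a chain one carbon shorter is a real change and the uncertainty is wide. The expected step is a 1.2-fold higher number from compound 1 to compound 3 (0.09 log units; within the scatter). For compound 3 the estimate is 12000 nM, ranging from 3500 nM to 40000 nM.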

Compound 3, half-maximal inhibitory concentration: 19000 nM
Estimate against measurement, compound 3: 1.6-fold (0.20 log units) below; measured number inside the range.
By their numbers in this assay, from the lowest: compounds 1, 2 and 3 (each within the scatter of the next).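

In this assay, among the compounds shown here, putting hydroxycarbamoyl in place of (hydroxycarbamoyl)methyl on the saturated chain carbon gives a 2.0-fold higher number from compound 1 to compound 3 (0.29 log units; within the scatter) and this is the first measured step on the chain that carries the hydroxycarbamoyl end rather than on the amide side of the molecule. A step of this size cannot separate compound 1 from compound 3, so this change to the chain leaves the number within the scatter, just as the change on the amide side did for compound 1 and compound 2. No measurement in hand bears on what lies behind this result.

The compounds shown leave open whether a longer chain, or a still shorter one such as 2-(hydroxycarbamoyl)ethyl at this place, would carry the number beyond the scatter. They also leave open what happens when the hydroxycarbamoyl end itself gives way to another group, such as a carboxylic acid or an amine, since every compound here keeps that end unchanged.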